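This account rests on a few compounds, and the source may have more. Where it says the series, first, only, none or still open, it means among the compounds named here.

Measured so far:

Compound 1, `CCS(=O)(=O)N[C@@H]1CCCN(C(C)=O)[C@H]1CO[C@H]1CC[C@H](C(C)C)CC1`, in a functional assay on CHO-K1 cells for agonist activity at Orexin/Hypocretin receptor type 1 (Homo sapiens), read by FLIPR and calcium flux (a lower number here means that less compound is needed, a higher number that more compound is needed for the effect), gives > 100000 nM.
Compound 2, `CC(=O)N1CCC[C@H](NS(C)(=O)=O)[C@@H]1CO[C@H]1CC[C@@H](C(C)C)CC1`, in this assay gives > 100000 nM.

Both of these results are limits of the assay, not numbers: for compound 1 the value > 100000 nM means no agonist effect was seen up to the highest concentration tested. For compound 2 the value > 100000 nM is a limit in the same way. Compound 2 therefore stands nowhere on a scale of numbers; it sits at the edge of what the assay can report, and so does its only companion, as the line the limit of > 100000 nM in this assay, at which 2 of the 2 values shown sit, sums up.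

Compound 3, `CC(=O)N1CCC[C@H](NC(=O)O)[C@@H]1CO[C@H]1CC[C@@H](C(C)C)CC1`, has not yet been measured. It differs from compound 2 in one place: carboxy in place of methylsulfonyl on an amine nitrogen, so the methanesulfonamido group becomes a carboxyamino group.

Among the compounds with values here, no measured step is available to show what such a change does here. With both measured compounds at the limit, the expectation for compound 3 is that it also stays near that limit, and the step of a number no higher from compound 2 to compound 3 (the limit leaves the size open) is expected to be none beyond the scatter. Compound 3 is estimated at 100000 nM, with a range from 30000 nM to 300000 nM.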

Compound 3, half-maximal effective concentration: > 100000 nM
Compound 3 gave a limit, no number; the forecaster's own chance of this, stated with the estimate: 85%; the middle value sits exactly at the limit.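

In this assay compound 3 gives > 100000 nM, which is a limit and not a number. No step can be read between compound 2 and compound 3, as both rest at the same edge of the assay: the limit of > 100000 nM in this assay, at which 3 of the 3 values shown sit. The compounds shown leave open what carboxy in place of methylsulfonyl does, and whether any compound sharing this core gives a measurable value.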